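A few compounds are considered here, and "the series" means these few. Any claim that something is new, unique, unknown or untested is made for them only; others in the source may bear on it.

Measured compounds:
Compound 1 `C=CC1=C(C(=O)NCCC)C(c2ccc(F)cc2)OC1`: in a functional assay on HeLa cells (Homo sapiens) for cytotoxicity, read by MTT assay, with a stated time of 24 h (on this read-out higher numbers stand for weaker inhibition and lower numbers for stronger inhibition), compound 1 gives > 100000 nM, a limit of the assay.
Compound 2 `C=CC1=C(C(=O)O)C(c2ccc(F)cc2)OC1`: in this assay compound 2 gives 67400 nM.
Compound 3 `C=CC1=C(C(=O)Nc2ccc(C)cc2)C(c2ccc(F)cc2)OC1`: in this assay compound 3 gives > 100000 nM, a limit of the assay.

Compound 3 thus stands at the limit, with no number of its own. Compound 4 `C=CC1=C(C(=O)NCCCCC)C(c2ccc(F)cc2)OC1` differs from it by pentyl in place of 4-methylphenyl on an amide-type nitrogen. The measured step that bears on this change is a step that the two limits leave unreadable from compound 1 to compound 3, which cannot be read because of the limit of > 100000 nM in this assay, at which 2 of the 3 values shown sit. The flanking steps an at least 1.4-fold lower number from compound 1 to compound 2 (0.17 log units; that floor lies within the scatter) and an at least 1.4-fold higher number from compound 2 to compound 3 (0.17 log units; that floor lies within the scatter) are each only a floor that lies within the scatter. Nothing in these numbers separates a propyl amide from a 4-methylphenyl amide, so for a pentyl amide the estimate is a step that the limit leaves unreadable from compound 3 to compound 4, with compound 4 expected to remain at the limit. Compound 4 is expected to give 150000 nM, with a range from 60000 nM to 400000 nM.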

Compound 4, half-maximal inhibitory concentration: > 100000 nM
Compound 4: no number, only a limit; the forecaster's own chance of this, stated with the estimate: 85%; the middle value is on the limit's open side.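

A pentyl chain on the amide-type nitrogen behaves no differently from the propyl and 4-methylphenyl groups, so an open-chain amide of this length also yields no number. Against the carboxylic acid of compound 2 there is an at least 1.4-fold higher number from compound 2 to compound 4 (0.17 log units; that floor lies within the scatter), a floor that lies within the scatter. The steps among compound 1, compound 3 and compound 4 cannot be read, because all three stand at a limit of the assay: the limit of > 100000 nM in this assay, at which 3 of the 4 values shown sit.

On these data alone, it remains open whether any amide gives a number in this assay. A much longer chain, a terminal amine or a methyl ester might show this.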